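Ethoxyphenyl placement across two related cores

This account rests on a few compounds, and the source may have more. Where it says the series, first, only, none or still open, it means among the compounds named here.

Compound 2 `CCOc1ccc(-n2nncc2CN2C(=O)C3(C(C#N)=C(N)Oc4c3c3nc5ccccc5nc3c3ccccc43)c3ccccc32)cc1` carries a 4-ethoxyphenyl group on the five-membered aromatic ring with 3 nitrogen; compound 1 `CCOc1ccccc1-n1nncc1CN1C(=O)C2(C(C#N)=C(N)Oc3c2c2nc4ccccc4nc2c2ccccc32)c2ccccc21` is its isomer, with 2-ethoxyphenyl in place of 4-ethoxyphenyl on an aromatic nitrogen. In a functional assay on MCF7 cells (Homo sapiens) for antiproliferative activity, read by MTT assay, with a stated time of 48 h (on this read-out lower numbers stand for stronger inhibition and higher numbers for weaker inhibition), compound 2 returns only a limit, > 50000 nM. Compound 1 likewise returns only a limit in this assay, namely > 50000 nM. The step that the two limits leave unreadable from compound 2 to compound 1 therefore cannot be sized, because of the limit of > 50000 nM in this assay, at which 2 of the 3 values shown sit.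

Compound 3 `CCOc1ccc(-n2nncc2CN2C(=O)C3(C(C#N)=C(N)Oc4c(N)cc5nc6ccccc6nc5c43)c3ccccc32)cc1` has a different core; the difference between its core and that of compound 2 is not broken down here. In this assay, among the compounds with values here, compound 3 gives 26800 nM, the one numerical value in the set.

Compound 4 `CCOc1ccccc1-n1nncc1CN1C(=O)C2(C(C#N)=C(N)Oc3c(N)cc4nc5ccccc5nc4c32)c2ccccc21` is not yet measured. It relates to compound 3 as compound 1 relates to compound 2: 2-ethoxyphenyl in place of 4-ethoxyphenyl on an aromatic nitrogen, the same change at the same place. The measured instance of this change left no readable size, so the expectation for compound 4 rests on compound 3 at 26800 nM alone. The expected step is a 1.1-fold higher number from compound 3 to compound 4 (0.05 log units; within the scatter). Compound 4 is accordingly estimated at 30000 nM in this assay, within 12000 nM to 80000 nM, with a real chance that only a limit is returned.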

Compound 4, half-maximal inhibitory concentration: > 50000 nM
Compound 4: a limit, no number (the forecaster's own chance of this, stated with the estimate: 40%); at least 1.6-fold (0.22 log units) between middle value and limit.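

In this assay, 2-ethoxyphenyl in place of 4-ethoxyphenyl on the aromatic nitrogen, carried onto the core of compound 3, gives an at least 1.8-fold higher number from compound 3 to compound 4 (0.27 log units; that floor lies within the scatter). This shows only a floor for the step: since that floor lies within the scatter, the result does not establish a real loss of activity on this core, and it gives no upper bound for the step. The matching step on the core of compound 2 cannot be read, so the size of the change cannot be compared between the two cores, and carrying it over is neither confirmed nor refuted because nearly all the data rest on one shared limit: the limit of > 50000 nM in this assay, at which 3 of the 4 values shown sit.

Within the data shown here, compound 3, at 26800 nM, still supplies the only number in the set, so no measured pair yet gives a full step size. As far as these compounds go, what a butoxy chain, a dimethylamino group or a carboxylic acid in place of the ethoxy would return on either core stays open.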